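Trifluoromethyl for Isopropyl: What to Expect of Compound 4

The compounds below may be only part of what the source reports. "The series", "measured", "known", "first", "only" and "open" are said of these compounds alone.

Compound 1 `CC(C)c1ccccc1NC(=O)N[C@@H](C)c1ccccc1`, compound 2 `CC(C)c1cccc(NC(=O)N[C@H](C)c2ccccc2)c1` and compound 3 `C[C@H](NC(=O)Nc1ccccc1C(F)(F)F)c1ccccc1` have all been measured in an ADME assay on the whole organism with Oryza sativa as the target, tested at 0.1 uM; a higher number here means a weaker effect of the compound at the concentration tested, a lower number a stronger effect. In this assay compound 1 gives 99%, compound 3 gives 97%, and compound 2 gives 74%, the lowest of the three, with its steps to both others beyond the scatter. Compound 1 and compound 2 share the same atoms joined differently; the difference between the two cores is not broken down here. From compound 1 to compound 3 the change is trifluoromethyl in place of isopropyl on an aromatic carbon, and the step it made was a number 2 percentage points lower from compound 1 to compound 3 (within the scatter). Compound 4 `C[C@@H](NC(=O)Nc1cccc(C(F)(F)F)c1)c1ccccc1` has not yet been measured; it differs from compound 2 by trifluoromethyl in place of isopropyl on an aromatic carbon, the same kind of change, though here the place is meta to a large group rather than ortho to a large group. Because a number 2 percentage points lower from compound 1 to compound 3 (within the scatter) lay within the scatter, a step of similar size is expected, namely a number 2 percentage points lower from compound 2 to compound 4 (within the scatter). Compound 4 is therefore estimated at 72%, likely between 58% and 86%.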

Compound 4, a percentage reported as activity, at one concentration (the size of the read-out at that concentration, not a potency): 82%
Estimate against measurement, compound 4: 10 percentage points below; the range from low to high includes it.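

In this assay, trifluoromethyl in place of isopropyl on an aromatic carbon gave a number 8 percentage points higher from compound 2 to compound 4 (within the scatter). Set beside the earlier step, the change reads alike on the two cores: the same change on two cores in this assay, a number 2 percentage points lower (within the scatter) from compound 1 to compound 3 and a number 8 percentage points higher (within the scatter) from compound 2 to compound 4, 10 percentage points apart, within the scatter of two such steps This shows only that neither step can be told from the scatter, so the swap made no readable difference on either core at the one concentration tested; it does not show that the change would stay as small on any other core, and two steps make no rule for the series.

The compounds shown carry only isopropyl and trifluoromethyl at these places. On these data alone, how a nitrile, an amine or a longer chain would read there remains open.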